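The source may report more compounds than this note shows. Statements on the series, on what has been measured and on what is new or still open speak of the compounds shown alone.

Two hydrazide-linked compounds, compound 1 `O=C(COc1c(F)cc(C(=O)c2ccc(F)cc2)cc1Cl)NNC(=O)c1ccc(=O)oc1` and compound 2 `Cn1cnc(C(=O)NNC(=O)COc2c(F)cc(C(=O)c3ccc(Cl)cc3)cc2Cl)c1`, have been tested in an ADME assay on NIH3T3 cells (Mus musculus) for cytotoxicity, read by LDH release, with a stated time of 48 h; on this read-out higher numbers stand for weaker inhibition and lower numbers for stronger inhibition. There compound 1 gives 89800 nM and compound 2 gives 89300 nM, so compound 2 stands level with compound 1 within the usual scatter. The next compound to be tested is compound 3 `O=C(COc1c(F)cc(C(=O)c2ccc(Cl)cc2)cc1Cl)NNC(=O)c1ccc(=O)oc1`. It is reached from compound 2 by one structural change: a group of 7 heavy atoms (5 carbon, 2 oxygen; one six-membered aromatic ring with 1 hetero atom) in place of a group of 6 heavy atoms (4 carbon, 2 nitrogen; one five-membered aromatic ring with 2 hetero atoms), on a carbonyl carbon. The swap takes place on a carbonyl carbon, and a six-membered aromatic ring with 1 hetero atom replaces a five-membered aromatic ring with 2 hetero atoms. Among the measured compounds shown here, no measured step isolates this change, so the expectation rests only on the closeness of the two values in this assay. The expected step is a 1.0-fold lower number from compound 2 to compound 3 (0.00 log units; within the scatter), which means no change beyond the scatter. For compound 3 the estimated value is 89000 nM, with an expected range from 45000 nM to 170000 nM.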

Compound 3, half-maximal inhibitory concentration: 78600 nM
The estimate for compound 3 lay 1.1-fold (0.05 log units) above the measured number; low and high end bracket the measured number.
By their numbers in this assay, from the lowest: compounds 3, 2 and 1 (each within the scatter of the next).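

In this assay, placing the six-membered aromatic ring on the carbonyl carbon in place of 1-methyl-1H-imidazol-4-yl gives a 1.1-fold lower number from compound 2 to compound 3 (0.06 log units; within the scatter). This position therefore accepts either ring, with a five-membered and a six-membered aromatic ring giving values within the scatter of each other. The second pair, with chloro in place of fluoro on an aromatic carbon, gives a 1.1-fold lower number from compound 1 to compound 3 (0.06 log units; within the scatter), so this halogen swap also stays within the scatter, and no measurement at hand explains either result.

As far as these compounds go, whether the level seen across these three compounds would hold with an amine or a carboxylic acid on the carbonyl carbon remains open. From the compounds shown here alone, it is also open whether a methoxy group on that aromatic carbon would stay within the scatter as chloro and fluoro do.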